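Iodo for amino on a chloro-bearing fused core

The source may hold more compounds than are shown below. What is called first, only, known or untested is meant among the compounds shown, and "the series" means these compounds.

All values below come from a functional assay on SW-620 cells (Homo sapiens) for inhibition; on this read-out higher numbers stand for weaker inhibition and lower numbers for stronger inhibition.

Compound 1 `CC(=O)OC(C)n1cnc2c(Cl)nc(N)nc21`: > 500000 nM; this is a limit of the assay, not a number.
Compound 2 `CC(=O)OCCOn1cnc2c(Cl)nc(N)nc21`: > 500000 nM; this is a limit of the assay, not a number.
Compound 3 `CC(=O)OC(C)n1cnc2c(Cl)nc(I)nc21`: 3550 nM.

Compound 1 and compound 3 share a core and differ in one place: iodo in place of amino on an aromatic carbon. This change produced an at least 140-fold lower number from compound 1 to compound 3 (2.14 log units; beyond the scatter). The size of that step is known only as a lower bound because of the limit of > 500000 nM in this assay, at which 2 of the 3 values shown sit.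

Compound 2 differs from compound 1 in more than one place; the difference between the two cores is not broken down here.

Compound 4 `CC(=O)OCCOn1cnc2c(Cl)nc(I)nc21` has not been measured in this assay. It stands to compound 2 as compound 3 stands to compound 1: iodo in place of amino on an aromatic carbon. The two place descriptions agree word for word, so this is the same change made a second time, occurring twice among the compounds shown.

For compound 2 only a limit is known, so the step to compound 4 cannot be anchored on a measured starting number. Going by the values given here, the expectation rests on compound 3, whose 3550 nM is the only number in the set, and on the size of the measured step of an at least 140-fold lower number from compound 1 to compound 3 (2.14 log units; beyond the scatter). For compound 4 the expected step is an at least 100-fold lower number from compound 2 to compound 4 (2.00 log units; beyond the scatter), to be set beside the measured one. Compound 4 is estimated at 5000 nM, with a likely range from 1500 nM to 30000 nM.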

Compound 4, half-maximal inhibitory concentration: 15800 nM
The estimate for compound 4 lay 3.2-fold (0.50 log units) below the measured number, within the range that was stated.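

Iodo in place of amino on an aromatic carbon again gives a large drop on the second core, an at least 31-fold lower number from compound 2 to compound 4 (1.50 log units; beyond the scatter), so in this assay the direction of the change holds on both cores shown, and no compound here goes against it. Going by these compounds alone, this is only two cores in one cell assay, and it does not show that the step has the same size on each: the same change on two cores in this assay, an at least 140-fold lower number (2.14 log units; beyond the scatter) from compound 1 to compound 3 and an at least 31-fold lower number (1.50 log units; beyond the scatter) from compound 2 to compound 4; the limit leaves it open whether they differ. From the compounds shown here alone, both steps are lower bounds, and the real size of the change on either core remains unknown because of the assay limit: the limit of > 500000 nM in this assay, at which 2 of the 4 values shown sit.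

The compounds shown leave open whether iodo is needed at this place between two ring nitrogen atoms, or whether bromo, a methyl group or a nitrile would also give a lower number than amino. They also leave open how the change behaves when the chloro group gives way to another group, such as a methoxy group or an amine, or when the acetate-bearing chain gives way to a longer chain or a carboxylic acid.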